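A Phenylpiperazine Takes the Place of the Thiadiazole Sulfide

The source may report more compounds than this note shows. Statements on the series, on what has been measured and on what is new or still open speak of the compounds shown alone.

Compound 2 `Cc1nnc(SCC(=O)Nc2ccc(-c3nc(-c4ccccc4)c(-c4ccccc4)n3C)cc2)s1` carries a (5-methyl-1,3,4-thiadiazol-2-yl)sulfanyl group on a saturated chain carbon bound to a carbonyl carbon. In a functional assay on MCF7 cells (Homo sapiens) for cytotoxicity, read by MTT assay, with a stated time of 24 h (on this read-out lower numbers stand for stronger inhibition and higher numbers for weaker inhibition), compound 2 gives 3.2 ug/mL, the lowest number of the three measured. Compound 1 `Cn1c(-c2ccc(NC(=O)CCl)cc2)nc(-c2ccccc2)c1-c1ccccc1`, which has chloro at that position, gives 42.6 ug/mL in this assay, and compound 3 `CN(C)/C=C/N1CCN(CC(=O)Nc2ccc(-c3nc(-c4ccccc4)c(-c4ccccc4)n3C)cc2)CC1`, with 4-(2-(dimethylamino)ethenyl)piperazin-1-yl there, gives 80 ug/mL. The step of a 13-fold lower number from compound 1 to compound 2 (1.12 log units; beyond the scatter) and the step of a 25-fold higher number from compound 2 to compound 3 (1.40 log units; beyond the scatter) both reach beyond the scatter, while a 1.9-fold higher number from compound 1 to compound 3 (0.27 log units; within the scatter) does not.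

Compound 4 `Cn1c(-c2ccc(NC(=O)CN3CCN(c4ccccc4)CC3)cc2)nc(-c2ccccc2)c1-c1ccccc1` differs from compound 2 by 4-phenylpiperazin-1-yl in place of (5-methyl-1,3,4-thiadiazol-2-yl)sulfanyl on a saturated chain carbon bound to a carbonyl carbon. The measured step that bears on it is a 25-fold higher number from compound 2 to compound 3 (1.40 log units; beyond the scatter), where the group entering at that position was also a piperazin-1-yl, and the number rose by a large amount. On that basis a rise in this assay is expected for compound 4 as well, though the phenyl on the piperazine has no measured precedent among these compounds, so the size of the step is uncertain. Compound 4 is therefore expected to give 30 ug/mL in this assay, within a range of 8 ug/mL to 100 ug/mL. The expected step is a 9.4-fold higher number from compound 2 to compound 4 (0.97 log units; beyond the scatter).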

Compound 4, half-maximal inhibitory concentration: 10.7 ug/mL
Estimate against measurement, compound 4: 2.8-fold (0.45 log units) above; measured number inside the range.
By their numbers in this assay, from the lowest: compound 2; then compound 4; then compounds 1 and 3 (each within the scatter of the next).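

The piperazine ring alone does not set the number at this position on a saturated chain carbon bound to a carbonyl carbon: with phenyl in place of 2-(dimethylamino)ethenyl on the ring's amine nitrogen, this assay shows a 7.5-fold lower number from compound 3 to compound 4 (0.87 log units; beyond the scatter), so the group carried on that nitrogen clearly counts. Compound 4 also gives the first piperazine step away from chloro that reaches beyond the scatter, a 4.0-fold lower number from compound 1 to compound 4 (0.60 log units; beyond the scatter), which compound 3 did not provide. Even so, 4-phenylpiperazin-1-yl does not match the (5-methyl-1,3,4-thiadiazol-2-yl)sulfanyl group, as a 3.3-fold higher number from compound 2 to compound 4 (0.52 log units; beyond the scatter) shows, and the sulfur-linked thiadiazole remains the group with the lowest number at this position.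

Nothing available accounts for these differences. From the compounds shown here alone, it remains open how a methyl, a benzyl or a 4-chlorophenyl on the piperazine nitrogen would compare with phenyl in this assay, and whether a morpholin-4-yl or a piperidin-1-yl at the chain carbon would behave as the piperazines do.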